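The source may report more compounds than this note shows. Statements on the series, on what has been measured and on what is new or still open speak of the compounds shown alone.

Working notes on the series, read in a functional assay on SK-MEL-28 cells (Homo sapiens) for cytotoxicity, read by MTT assay; a higher number here means a weaker inhibitor, a lower number a stronger inhibitor. Compound 1 `O=S(=O)(NCCCNc1nccc(-c2c(-c3cccc(F)c3)nc3sccn23)n1)c1cccc(F)c1` gives 8550 nM in this assay. Compound 2 `O=S(=O)(NCCNc1nccc(-c2c(-c3cccc(F)c3)nc3sccn23)n1)c1ccc(Cl)cc1` gives 18600 nM in this assay. Compound 3 `Cc1ccc(S(=O)(=O)NCCNc2nccc(-c3c(-c4cccc(F)c4)nc4sccn34)n2)cc1` reaches only a limit of this assay, > 20000 nM, so no number is known for it. This sits at the limit of > 20000 nM in this assay, at which 1 of the 3 values shown sits. The steps run a 2.2-fold higher number from compound 1 to compound 2 (0.34 log units; beyond the scatter) and an at least 2.3-fold higher number from compound 1 to compound 3 (0.36 log units; beyond the scatter), while between the two shorter-chain compounds an at least 1.0-fold higher number from compound 2 to compound 3 (0.03 log units; that floor lies within the scatter). Compound 3 therefore stands at the weak edge of the measured set: separated from compound 1 beyond the scatter, not separable from compound 2.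

Compound 4 `O=S(=O)(NCCNc1nccc(-c2c(-c3cccc(F)c3)nc3sccn23)n1)c1cccc(F)c1` differs from compound 3 by 3-fluorophenyl in place of 4-methylphenyl on a sulfonyl sulfur. Among the compounds with values here, no measured step isolates this aryl change on the shorter chain; both steps from compound 1 bundle the chain shortening with an aryl change, and the one pure aryl comparison, chloro against methyl, stays within the scatter. The expectation for compound 4 is therefore a small step, an at least 1.3-fold lower number from compound 3 to compound 4 (0.12 log units; that floor lies within the scatter), with no clear direction beyond the scatter. The estimate for compound 4 in this assay is 15000 nM, within 6000 nM to 40000 nM.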

Compound 4, half-maximal inhibitory concentration: 18300 nM
The estimate for compound 4 lay 1.2-fold (0.09 log units) below the measured number; low and high end bracket the measured number.
By their numbers in this assay, from the lowest: compound 1; then compounds 4 and 2 (each within the scatter of the next). At a limit, above all of these: compound 3.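

With 3-fluorophenyl held on the sulfonyl sulfur, the chain change now stands alone in this assay (a 2.1-fold higher number from compound 1 to compound 4 (0.33 log units; beyond the scatter)), whereas both earlier steps from compound 1 bundled it with an aryl change. On the shorter chain, 3-fluorophenyl in place of 4-chlorophenyl does not separate the two compounds (a 1.0-fold lower number from compound 2 to compound 4 (0.01 log units; within the scatter)), so compound 1 remains apart from compound 2 and compound 4 alike, and no aryl preference appears at this sulfonyl sulfur. The comparison with 4-methylphenyl (an at least 1.0-fold lower number from compound 3 to compound 4 (0.03 log units; that floor lies within the scatter)) adds no separation, and compound 3 remains a limit of the assay, not a number: (the limit of > 20000 nM in this assay, at which 1 of the 4 values shown sits).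

Open, as far as these compounds go, is whether the chain step holds with 4-chlorophenyl or 4-methylphenyl on the sulfonyl sulfur, and whether a still longer chain extends it. Also open, from the compounds shown here alone, is whether an amine or a carboxylic acid on the aryl ring would move the number beyond the scatter.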